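Notes on a pyrazole substituent swap in a benzamide series

The source may report more compounds than this note shows. Statements on the series, on what has been measured and on what is new or still open speak of the compounds shown alone.

Measured so far:
compound 1 `Cc1ccc(C(=O)Nc2cc(CN3CCN(C)CC3)cc(C(F)(F)F)c2)cc1-c1ccc2cn[nH]c2c1` 4.7 nM
compound 2 `Cc1ccc(C(=O)Nc2cc(CN3CCN(C4CCCC4)CC3)cc(C(F)(F)F)c2)cc1-c1ccc2cn[nH]c2c1` 7 nM
compound 3 `CCCn1cc(-c2n[nH]c3cc(-c4cc(C(=O)Nc5cccc(C(F)(F)F)c5)ccc4C)ccc23)cn1` 3.2 nM

All three were read in an assay on isolated protein for inhibition of Discoidin domain-containing receptor 2 (Homo sapiens), read by ELISA, with a stated time of 60 min; on this read-out higher numbers stand for weaker inhibition and lower numbers for stronger inhibition. Compound 3 gives the lowest number of the three; its gap to compound 1 lies within the scatter, while its gap to compound 2 is just beyond it. Among the compounds with values here, the only single-point step measured, a 1.5-fold higher number from compound 1 to compound 2 (0.17 log units; within the scatter), concerns a substituent on the amine nitrogen in a ring of the left-hand side and changes the read-out within the scatter.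

Compound 4 `Cc1ccc(C(=O)Nc2cccc(C(F)(F)F)c2)cc1-c1ccc2c(-c3cnn(C4CCCCO4)c3)n[nH]c2c1` differs from compound 3 at the pyrazole end: oxan-2-yl in place of propyl on an aromatic nitrogen. Within the data shown here, no measured pair carries this change or anything at that position, so the step from compound 1 to compound 2 bears on it only indirectly, as an example of a ring-nitrogen substituent swap elsewhere that left the read-out within scatter. Among the measured compounds shown here, with the pyrazole substituent being the only variable and compound 3 at 3.2 nM as the anchor, the expected step of a 1.3-fold higher number from compound 3 to compound 4 (0.10 log units; within the scatter) is none beyond the scatter. Compound 4 is therefore estimated at 4 nM, with a range from 1.5 nM to 11 nM in this assay.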

Compound 4, half-maximal inhibitory concentration: 5.2 nM
Compound 4: the middle estimate sits 1.3-fold (0.11 log units) below what was measured, and the stated range covers the measured number.
By their numbers in this assay, from the lowest: compounds 3, 1, 4 and 2 (each within the scatter of the next, the first and the last beyond it).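

Within the data shown here, this is the first direct reading at the aromatic nitrogen of the pyrazole: in this assay, oxan-2-yl in place of propyl gives a 1.6-fold higher number from compound 3 to compound 4 (0.21 log units; within the scatter) and so stays within the scatter. The position therefore accepts a six-membered non-aromatic ring with one oxygen, carrying 6 heavy atoms and one hydrogen-bond acceptor, in place of an open chain of 3 carbons, with no read-out change that can be separated from repeat noise. With one pair behind it, this describes these two substituents on this core and sets no limit on the size or type of group accepted at this nitrogen, and nothing available explains the result.

Still open, as far as these compounds go, is whether the same flat response holds for other groups on this nitrogen, such as a bare hydrogen, a methyl group, a longer chain ending in a primary amine, or a carboxylic acid, any of which would show whether the position responds at all. Also open, from the compounds shown here alone, is whether propyl and oxan-2-yl on the pyrazole read alike when the methylpiperazine-type side chain of compound 1 is present on the benzamide ring.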